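Cytotoxicity of a pyridin-2-yl analogue: what to expect

The source may hold more compounds than are shown below. What is called first, only, known or untested is meant among the compounds shown, and "the series" means these compounds.

Three compounds have been measured in an ADME assay on HEK293 cells (Homo sapiens) for cytotoxicity, read by MTT assay, with a stated time of 24 h; on this read-out higher numbers stand for weaker inhibition and lower numbers for stronger inhibition:

Compound 1, `O=C1NC(O)(CCn2cc(C3=CCCCC3)nn2)C(OCc2ccccc2)=C1OCc1ccccc1`, gives 70000 nM.
Compound 2, `CC(C)(C)c1ccc(-c2cn(C/C=C3\OC(=O)C(OCc4ccccc4)=C3OCc3ccccc3)nn2)cc1`, gives > 100000 nM, which is a limit of the assay rather than a number.
Compound 3, `Cc1ccc(-c2cn(C/C=C3\OC(=O)C(OCc4ccccc4)=C3OCc3ccccc3)nn2)cc1`, gives > 100000 nM, again a limit of the assay.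

Compound 3 thus stands at the weak end of what was recorded: its own value is a limit, and only compound 1 yields a number in this assay at all. Among the measured compounds shown here, the one single-point step among the measured compounds, a step that the two limits leave unreadable from compound 2 to compound 3, cannot be sized, because the limit of > 100000 nM in this assay, at which 2 of the 3 values shown sit, caps both ends of it.

Compound 4, `O=C1O/C(=C\Cn2cc(-c3ccccn3)nn2)C(OCc2ccccc2)=C1OCc1ccccc1`, is yet to be measured in this assay. It differs from compound 3 in one place: pyridin-2-yl in place of 4-methylphenyl on an aromatic carbon. For the measured compounds named here, no measured step bears directly on this change, and the only step that comes close, from compound 2 to compound 3, is hidden by the limit.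

Accordingly compound 4 is expected to sit where compound 3 sits, with no step beyond the scatter: a number no higher from compound 3 to compound 4 (the limit leaves the size open). The estimate for compound 4 in this assay is 100000 nM, with a range from 50000 nM to 300000 nM, and a fair chance that the assay again reports only a limit.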

Compound 4, half-maximal inhibitory concentration: > 100000 nM
Compound 4 ended at the assay's limit (the forecaster's own chance of this, stated with the estimate: 60%); the middle value lies on the limit itself.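

No new step can be read: the comparisons of compound 4 with compound 3 and with compound 2 remain unreadable, because all three compounds end at one and the same limit rather than at a number: the limit of > 100000 nM in this assay, at which 3 of the 4 values shown sit.

The compounds shown leave open how far each of the three lies beyond that limit, and so whether pyridin-2-yl in place of 4-methylphenyl changes the read-out at all.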